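Shortening the chain on the triazene nitrogen of compound 1

The source may report more compounds than this note shows. Statements on the series, on what has been measured and on what is new or still open speak of the compounds shown alone.

Measured so far:
compound 1, `CCCCCCCCN(C)/N=N/c1ccc(C(N)=O)cc1`: 2.84
compound 2, `CCCCOC(=O)c1[nH]cnc1/N=N/N(C)C`: 3.53
compound 3, `CC(=O)N(C)/N=N/c1ccc(C)cc1`: 2.78

In a functional assay on L1210 cells (Mus musculus) for antiproliferative activity (on this read-out lower numbers stand for lower potency and higher numbers for higher potency (the scale is a negative logarithm)), compound 1 gives 2.84, the second highest of the three numbers. Compound 3 is within the scatter of it, so no order between them can be read, whereas compound 2 stands beyond the scatter above both.

Compound 4, `CCN(C)/N=N/c1ccc(C(N)=O)cc1`, has not been measured. It differs from compound 1 by hydrogen in place of hexyl on a saturated chain carbon, two bonds along the chain from an amine nitrogen. For the measured compounds named here, no measured pair shows a step of this kind, so the direction has to be guessed. The expectation is a small step, if any, from compound 1 to compound 4, a number 0.06 log units higher from compound 1 to compound 4 (within the scatter), and not one beyond the scatter. Compound 4 is therefore estimated at 2.9, with a range from 2.4 to 3.5.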

Compound 4, logarithm of the reciprocal of the active concentration, log(1/C): 3.66
Estimate against measurement, compound 4: 0.76 log units below, outside the stated range (above it).
By their numbers in this assay, from the lowest: compounds 3 and 1 (each within the scatter of the next); then compounds 2 and 4 (each within the scatter of the next).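

In this assay, putting hydrogen in place of hexyl gives a number 0.82 log units higher from compound 1 to compound 4 (beyond the scatter) and so shows that this part of the chain matters. For the compounds shown here, it is the first single change in this set that can be read, and here the shorter chain goes with the higher number. Nothing measured here explains the step.

On these data alone, only the two extremes of this chain are compared, so it remains open whether propyl in place of hexyl would give an intermediate number. Also open, as far as these compounds go, is how an amine or a carboxylic acid would behave at this place.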